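Shortening the side chain of a benzofuran hydroxamate

The source may report more compounds than this note shows. Statements on the series, on what has been measured and on what is new or still open speak of the compounds shown alone.

Compound 3 `CCOC(=O)CCC(=O)N(O)C(C)c1ccc2oc(-c3ccccc3)cc2c1` has the lowest number of the three measured compounds in an assay on RBL cells for inhibition of Polyunsaturated fatty acid 5-lipoxygenase (Rattus norvegicus) (a higher number here means a weaker inhibitor, a lower number a stronger inhibitor), with 50 nM. Compound 2 `CC(=O)OCC(=O)N(O)C(C)c1ccc2oc(-c3ccccc3)cc2c1` gives 160 nM and compound 1 `CC(=O)N(O)C(C)c1ccc2oc(-c3ccccc3)cc2c1` gives 490 nM. Compound 4 `COCC(=O)N(O)C(C)c1ccc2oc(-c3ccccc3)cc2c1` differs from compound 3 by methoxy in place of (ethoxycarbonyl)methyl on a saturated chain carbon bound to a carbonyl carbon. Among the measured compounds shown here, the steps that bear on this change are a 9.8-fold lower number from compound 1 to compound 3 (0.99 log units; beyond the scatter) and a 3.2-fold lower number from compound 2 to compound 3 (0.51 log units; beyond the scatter), while a 3.1-fold lower number from compound 1 to compound 2 (0.49 log units; beyond the scatter) shows that acetoxy at this place also lowered the number relative to hydrogen. Because a 3.2-fold lower number from compound 2 to compound 3 (0.51 log units; beyond the scatter) favours the (ethoxycarbonyl)methyl group over a shorter oxygen-containing substituent, the change to compound 4 is expected to give back part of that gain, a modest rise in this assay of a 3.6-fold higher number from compound 3 to compound 4 (0.56 log units; beyond the scatter). Compound 4 is therefore estimated at 180 nM, with a range from 70 nM to 450 nM.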

Compound 4, half-maximal inhibitory concentration: 160 nM
Beside the measured number, compound 4's estimate is 1.1-fold (0.05 log units) above it; low and high end bracket the measured number.
By their numbers in this assay, from the lowest: compound 3; then compounds 2 and 4 (each within the scatter of the next); then compound 1.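

In this assay methoxy on this saturated chain carbon bound to a carbonyl carbon still lowers the number relative to hydrogen (a 3.1-fold lower number from compound 1 to compound 4 (0.49 log units; beyond the scatter)), but it does not reach the number given by (ethoxycarbonyl)methyl (a 3.2-fold higher number from compound 3 to compound 4 (0.51 log units; beyond the scatter)). The acetoxy and methoxy compounds cannot be told apart (no change at the digits printed from compound 2 to compound 4 (within the scatter)), which shows that methyl can stand in place of acetyl on that oxygen without a measurable difference. Nothing available explains these differences. Going by these compounds, it remains open how an amine or a carboxylic acid at this place would compare, and whether a longer ether chain would approach compound 3.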